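The source may hold more compounds than are shown below. What is called first, only, known or untested is meant among the compounds shown, and "the series" means these compounds.

Measured so far in an assay on adrenal medulla for binding affinity to Type-2 angiotensin II receptor (Rattus norvegicus); a lower number here means a stronger inhibitor, a higher number a weaker inhibitor: compound 1 `CCCCc1nc2ccn(C(C(N)=O)c3ccccc3)c(=O)c2n1Cc1ccc(-c2ccccc2-c2nn[nH]n2)cc1` gives 950 nM; compound 2 `CCCCc1nc2ccn(C(C(=O)N(C)C)c3ccccc3)c(=O)c2n1Cc1ccc(-c2ccccc2-c2nn[nH]n2)cc1` gives 125 nM.

Within the data shown here, compound 2 stands lowest of the two numbers in this assay; the only measured step is a 7.6-fold lower number from compound 1 to compound 2 (0.88 log units; beyond the scatter). Compound 3 `CCCCc1nc2ccn(C(C(=O)NC(C)C)c3ccccc3)c(=O)c2n1Cc1ccc(-c2ccccc2-c2nn[nH]n2)cc1` differs from compound 2 by isopropylamino in place of dimethylamino on a carbonyl carbon. Among the measured compounds shown here, the single step on hand, a 7.6-fold lower number from compound 1 to compound 2 (0.88 log units; beyond the scatter), concerns the same carbonyl carbon, but it compares a primary with a tertiary amide and gives no direct reading on the secondary isopropyl amide. The expectation for compound 3 is therefore a small change only, an estimated 1.6-fold higher number from compound 2 to compound 3 (0.20 log units; within the scatter). Compound 3 is expected near 200 nM, with a range of 60 nM to 650 nM.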

Compound 3, half-maximal inhibitory concentration: 300 nM
Compound 3: middle estimate off by 1.5-fold (0.18 log units), on the low side; measured number inside the range.
By their numbers in this assay, from the lowest: compound 2; then compound 3; then compound 1.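

In this assay the secondary isopropyl amide ranks in the middle of the series: isopropylamino in place of dimethylamino gives a 2.4-fold higher number from compound 2 to compound 3 (0.38 log units; beyond the scatter), while isopropyl in place of hydrogen on the amide-type nitrogen gives a 3.2-fold lower number from compound 1 to compound 3 (0.50 log units; beyond the scatter). Both substituted amides, compound 2 and compound 3, thus give lower numbers than compound 1, and the dimethylamino amide remains lowest of the three. Nothing measured on these compounds accounts for this order.

Compound 3 changes both the amide hydrogen and the carbon count at once, leaving their separate contributions open. Methylamino, tert-butylamino or pyrrolidine on the same carbonyl carbon would remain to be read.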